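The source may hold more compounds than are shown below. What is called first, only, known or untested is meant among the compounds shown, and "the series" means these compounds.

Measured so far in an assay on CHO-K1 cells for displacement of a labelled ligand from prostaglandin E2 receptor EP1 subtype (Homo sapiens); on this read-out lower numbers stand for stronger inhibition and higher numbers for weaker inhibition:
compound 1 `Cc1cc(C(=O)NC(C)C)nn1Cc1cc(Cl)ccc1OCc1ccccc1` gives 126 nM
compound 2 `Cc1cc(NC(=O)C(C)C)nn1Cc1cc(Cl)ccc1OCc1ccccc1` gives 25.1 nM
compound 3 `Cc1cc(NC(=O)OCc2ccccn2)nn1Cc1cc(Cl)ccc1OCc1ccccc1` gives 79.4 nM

Compound 3 holds the second highest of the three numbers: a 1.6-fold lower number from compound 1 to compound 3 (0.20 log units; within the scatter), whereas a 3.2-fold higher number from compound 2 to compound 3 (0.50 log units; beyond the scatter). Compound 4 `Cc1cc(NC(=O)OCC(C)C)nn1Cc1cc(Cl)ccc1OCc1ccccc1` differs from compound 3 by isopropyl in place of pyridin-2-yl on a saturated chain carbon bound to an oxygen next to a carbonyl group. Among the measured compounds shown here, no measured pair shows exactly this change. For the measured compounds named here, the nearest step is the one from compound 2 to compound 3, where the pyridin-2-ylmethoxy group entered on the carbonyl carbon and the number rose. Compound 4 keeps the carbamate of compound 3 but carries an alkyl chain, as compound 2 does on its carbonyl carbon, so because of a 3.2-fold higher number from compound 2 to compound 3 (0.50 log units; beyond the scatter) part of that rise is expected to reverse. For compound 4 the expected step is a 1.6-fold lower number from compound 3 to compound 4 (0.20 log units; within the scatter) in this assay. For compound 4 the estimate is 50 nM, with a range from 20 nM to 125 nM.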

Compound 4, half-maximal inhibitory concentration in the prostaglandin E2 receptor EP1 subtype assay: 25.1 nM
Beside the measured number, compound 4's estimate is 2.0-fold (0.30 log units) above it; the range from low to high includes it.
By their numbers in the prostaglandin E2 receptor EP1 subtype assay, from the lowest: compounds 2 and 4 (each within the scatter of the next); then compounds 3 and 1 (each within the scatter of the next).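

At this saturated chain carbon bound to an oxygen next to a carbonyl group, isopropyl in place of pyridin-2-yl matters in the prostaglandin E2 receptor EP1 subtype assay (a 3.2-fold lower number from compound 3 to compound 4 (0.50 log units; beyond the scatter)), so the higher number of compound 3 (79.4 nM) goes with the pyridin-2-yl and not with the carbamate itself. On the carbonyl carbon, isobutoxy and isopropyl read alike (no change at the digits printed from compound 2 to compound 4 (within the scatter)), and the gain over the isopropylcarbamoyl group returns (a 5.0-fold lower number from compound 1 to compound 4 (0.70 log units; beyond the scatter)). In a physicochemical assay for lipophilicity, at pH 7.4 (on this read-out higher numbers stand for higher lipophilicity and lower numbers for lower lipophilicity), compound 3 gives 3.1 and compound 4 gives 3.3, so the same change gives (a number 0.20 log units higher from compound 3 to compound 4 (within the scatter)), and nothing available here accounts for the binding step.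

From the compounds shown here alone, whether the ring or its nitrogen sets the step stays open; phenyl at this place would separate the two. Going by these compounds, how a longer chain or a terminal amine would read here is also open.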